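This account rests on a few compounds, and the source may have more. Where it says the series, first, only, none or still open, it means among the compounds named here.

Within the data shown here, in a functional assay on Huh-7 cells (Homo sapiens) for cytotoxicity, with a stated time of 48 h (on this read-out higher numbers stand for weaker inhibition and lower numbers for stronger inhibition), compound 1 `COc1cc(OC)c(C(=O)/C=C/c2ccccc2)c(OC)c1` gives 15500 nM, the only exact number available so far. Compound 2 `COc1cc(O)c(C(=O)/C=C/c2ccccc2OC)c(OC)c1` reads > 20000 nM, which is a limit of the assay and not a number. Compound 3 `COc1cc(OC)c(C(=O)/C=C/c2ccc(Br)cc2)c(OC)c1` keeps the core of compound 1 and changes one place: bromo in place of hydrogen on an aromatic carbon. Among the measured compounds shown here, no measured pair shows what such a change does. In this assay, a modest expected step towards stronger inhibition, a 1.6-fold lower number from compound 1 to compound 3 (0.19 log units; within the scatter), is therefore estimated, and it may not exceed the scatter. For compound 3 the expected value is 10000 nM, with an estimated range of 4000 nM to 22000 nM.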

Compound 3, half-maximal inhibitory concentration: 13900 nM
For compound 3 the middle estimate is 1.4-fold (0.14 log units) below the measured one; the range from low to high includes it.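

In this assay, among these compounds, this is the first measured step for putting bromo in place of hydrogen on an aromatic carbon, para to a large group: a 1.1-fold lower number from compound 1 to compound 3 (0.05 log units; within the scatter). Going from phenyl to 4-bromophenyl on the shared core therefore gives two compounds that this read-out cannot tell apart. Compound 2 reads as a limit of the assay and not a number: the limit of > 20000 nM in this assay, at which 1 of the 3 values shown sits.

As far as these compounds go, it remains open whether a different group at this place, such as an amine or a carboxylic acid, would give a step beyond the scatter. One bromo also says nothing about the other carbons of this ring.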